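The compounds below may be only part of what the source reports. "The series", "measured", "known", "first", "only" and "open" are said of these compounds alone.

Measured so far:
compound 1 `COc1ccc(C(=O)/C=C/c2cccc(F)c2)c2c1C=CC(C)(C)O2` — > 10000 nM
compound 2 `COc1ccc(C(=O)/C=C/c2ccc3ccccc3c2)c2c1C=CC(C)(C)O2` — 5820 nM

In a functional assay on HCT-116 cells (Homo sapiens) for antiproliferative activity, read by MTT assay, with a stated time of 24 h (a lower number here means a stronger inhibitor, a higher number a weaker inhibitor), compound 1 sits at the limit of > 10000 nM in this assay, at which 1 of the 2 values shown sits; that value is a limit of the assay, not a number, so only a range is known for compound 1. Compound 2 does return a number in this assay, 5820 nM. Going by the values given here, the two measured compounds differ in more than one place, so no step between them is taken as a guide.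

Compound 3 `COc1ccc(C(=O)/C=C/c2cc(Cl)ccc2O)c2c1C=CC(C)(C)O2` has not yet been measured in this assay. Its difference from compound 1 is counted as 5-chloro-2-hydroxyphenyl in place of 3-fluorophenyl on a double-bonded chain carbon bound to a double-bonded chain carbon. Among the compounds with values here, the entering group brings a hydrogen-bond donor and a hydrogen-bond acceptor that the leaving group lacks, but no measured step shows what such a change does. Within the data shown here, the only anchor is that compound 1 stands at a limit, so a step toward stronger inhibition is possible but not required. The expected step is estimated at an at least 1.2-fold lower number from compound 1 to compound 3 (0.09 log units; that floor lies within the scatter), a change within the scatter or only slightly beyond it.

Compound 3 is therefore estimated at 8000 nM, with a range from 3000 nM to 30000 nM.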

Compound 3, half-maximal inhibitory concentration: 5240 nM
Estimate against measurement, compound 3: 1.5-fold (0.18 log units) above; measured number inside the range.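

In this assay this position now gives a step that can be read: 5-chloro-2-hydroxyphenyl in place of 3-fluorophenyl on a double-bonded chain carbon bound to a double-bonded chain carbon gives an at least 1.9-fold lower number from compound 1 to compound 3 (0.28 log units; that floor lies within the scatter), and that floor alone does not establish a change beyond the scatter. As far as these compounds go, compound 1 stands at > 10000 nM, which is a limit and not a number, so the step is known only as a floor and its full size stays unknown: the limit of > 10000 nM in this assay, at which 1 of the 3 values shown sits. The entering group differs from the leaving group in its chlorine, its oxygen and its hydrogen-bond donor and acceptor all at once, so this single step cannot be assigned to any one of these features.

From the compounds shown here alone, it remains open whether the hydroxyl or the chlorine carries the step, a question that a phenyl bearing only one of the two would address. It is also open how a group of another kind at this place, such as an amine or a carboxylic acid, would read in this assay, since the compounds shown carry only substituted aromatic rings here.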